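The source may hold more compounds than are shown below. What is called first, only, known or untested is meant among the compounds shown, and "the series" means these compounds.

Measured so far in an ADME assay on the whole organism (plasma, strain Balb/c) for pharmacokinetics, with Mus musculus as the target, at a dose of 10 mg/kg by the intravenous route; a lower number here means less compound in the circulation, a higher number more compound in the circulation at the dose given:
compound 1 `O=C(CCC1=CCN(Cc2ccc(F)cc2)C1=O)NO` gives 1280 ng.h/mL
compound 2 `O=C(CCC1=CCN(Cc2ccc(Br)cc2)C1=O)NO` gives 2330 ng.h/mL

Within the data shown here, compound 2 and compound 1 sit within the scatter of each other, the only measured step being a 1.8-fold higher number from compound 1 to compound 2 (0.26 log units; within the scatter). Compound 3 `CC(C)(C)c1ccc(CN2CC=C(CCC(=O)NO)C2=O)cc1` is the next step out from compound 2, differing in one place: tert-butyl in place of bromo on an aromatic carbon. Among the measured compounds shown here, the one measured step, bromo in place of fluoro on an aromatic carbon, changed the substituent at the same kind of position and stayed within the scatter; no measured step speaks to tert-butyl in place of bromo itself, so the precedent is indirect. On that footing no move beyond the scatter is expected in this assay, and the estimated step is a 1.2-fold lower number from compound 2 to compound 3 (0.07 log units; within the scatter). Compound 3 is therefore estimated at 2000 ng.h/mL, with a range from 800 ng.h/mL to 5000 ng.h/mL.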

Compound 3, area under the concentration-time curve: 3440 ng.h/mL
Estimate against measurement, compound 3: 1.7-fold (0.24 log units) below; the measured number falls inside the stated range.
By their numbers in this assay, from the lowest: compounds 1, 2 and 3 (each within the scatter of the next, the first and the last beyond it).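

In this assay the place on the aromatic ring takes tert-butyl, with four heavy atoms where bromo had one, and a 1.5-fold higher number from compound 2 to compound 3 (0.17 log units; within the scatter) stays small enough that these two groups cannot be told apart. Set against fluoro, the same group gives a 2.7-fold higher number from compound 1 to compound 3 (0.43 log units; beyond the scatter) and this modest step is the first in the series to clear the scatter, so a change at this one place can register in the read-out, though only between the two ends of the set. No measured property of these compounds is available to account for the step.

As far as these compounds go, whether an amine or a carboxylic acid at this place would stay in the same range remains open. So does the effect of any change away from this ring, on the shared core or on the chain bearing the hydroxamic acid.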